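This account rests on a few compounds, and the source may have more. Where it says the series, first, only, none or still open, it means among the compounds named here.

Two compounds carry the shared core in an assay on Cerebral cortex for binding affinity to adenosine receptor A1 (Cavia porcellus), read by radioligand binding; a lower number here means a stronger inhibitor, a higher number a weaker inhibitor. Compound 1 `CCCn1c(=O)n(CCO)c(=O)c2[nH]cnc21` gives 50000 nM. Compound 2 `CCCn1c(=O)n(C)c(=O)c2c1ncn2CC#N` gives 6600 nM, the lower of the two numbers, with compound 1 as its nearest neighbour at a difference beyond the scatter. Compound 3 `CCCn1c(=O)n(C)c(=O)c2c1ncn2CCCO`, not yet measured, differs from compound 2 by 2-hydroxyethyl in place of cyano on a saturated chain carbon bound to an aromatic nitrogen. Going by the values given here, no measured pair shows this change, so the size of its effect in this assay is unknown; the step from compound 2 to compound 3 is expected to be small, most likely toward a higher number, and may fall within the scatter. For compound 3 the expected inhibition constant is 10000 nM, between 3000 nM and 40000 nM, which means a step of a 1.5-fold higher number from compound 2 to compound 3 (0.18 log units; within the scatter).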

Compound 3, inhibition constant: 112000 nM
Compound 3: middle estimate off by 11-fold (1.05 log units), on the low side, and the stated range ends below it.
By their numbers in this assay, from the lowest: compound 2; then compound 1; then compound 3.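

In this assay, 2-hydroxyethyl in place of cyano on a saturated chain carbon bound to an aromatic nitrogen gives a 17-fold higher number from compound 2 to compound 3 (1.23 log units; beyond the scatter) and so provides the first size read for a change at this place. The place is not indifferent to what it carries: cyanomethyl and 3-hydroxypropyl give clearly different numbers.

Still open, from the compounds shown here alone, is how an amine or a carboxylic acid at the end of this chain would read, and whether an unsubstituted propyl chain would stay with compound 2 or with compound 3. Nothing at hand explains the size of this step.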